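The source may report more compounds than this note shows. Statements on the series, on what has been measured and on what is new or still open speak of the compounds shown alone.

Four compounds share one core. Compound 1 `Cc1c(C(=O)CSCCO)[n+]([O-])c2ccccc2[n+]1[O-]` and compound 3 `Cc1c(C(=O)CSCCNC(=O)C2CCCCC2)[n+]([O-])c2ccccc2[n+]1[O-]` carry no number in an ADME assay on Vero cells (Chlorocebus sabaeus) for cytotoxicity, read by MTT assay, with a stated time of 72 h; on this read-out lower numbers stand for higher toxicity in this test and higher numbers for lower toxicity in this test: compound 1 is recorded as "not determined" (no result reported) and compound 3 as "not determined" (no result reported). Compound 2 `COc1ccc(C(=O)NCCSCC(=O)c2c(C)[n+]([O-])c3ccccc3[n+]2[O-])cc1` is the single entry with a reported value, and that value is a limit of the assay: compound 2 gives > 100 ug/mL. So compound 3 stands without a number, next to one limit and one other blank entry, a setting summed up by the limit of > 100 ug/mL in this assay, at which 1 of the 3 values shown sits. Compound 4 `Cc1c(C(=O)CSCCNC(=O)c2cccs2)[n+]([O-])c2ccccc2[n+]1[O-]` differs from compound 3 in one place: thiophen-2-yl in place of cyclohexyl on a carbonyl carbon. Within the data shown here, with no measured step to lean on, no shift beyond the usual scatter is expected in this assay. Compound 4 is therefore expected to give about 100 ug/mL, somewhere between 50 ug/mL and 200 ug/mL, quite possibly again only as a limit.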

Compound 4, half-maximal cytotoxic concentration: > 100 ug/mL
Compound 4 was reported as a limit (the forecaster's own chance of this, stated with the estimate: 70%); the middle value lies on the limit itself.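

No step can be read between compound 2 and compound 4, as both are reported only as limits: the limit of > 100 ug/mL in this assay, at which 2 of the 4 values shown sit.

The compounds shown leave open whether thiophen-2-yl and 4-methoxyphenyl on a carbonyl carbon differ at all in cytotoxicity.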